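A few compounds are considered here, and "the series" means these few. Any claim that something is new, unique, unknown or untested is made for them only; others in the source may bear on it.

Of the compounds shown here, three built on one shared core have been tested in a functional assay on SF-539 cells (Homo sapiens) for inhibition, read by sulforhodamine B assay, with a stated time of 48 h, tested at 10 uM; on this read-out higher numbers stand for a weaker effect at the one concentration tested and lower numbers for a stronger effect. Compound 1 `O=C(Nc1cccc(-n2cc(-c3ccncc3)c(-c3cc(O)cc(Cl)c3)n2)c1)Nc1ccc(Cl)c(Cl)c1` gives -29% in this assay. Compound 2 `COc1cc(Cl)cc(-c2nn(-c3cccc(NC(=O)Nc4ccc(Cl)c(Cl)c4)c3)cc2-c2ccncc2)c1` gives 21% in this assay. Compound 2 differs from compound 1 by methyl in place of hydrogen on an oxygen on an aromatic ring, and this single change produced a number 50 percentage points higher from compound 1 to compound 2 (beyond the scatter). Compound 3 `O=C(Nc1cccc(-n2cc(-c3ccncc3)c(-c3cc(O)cc(Cl)c3)n2)c1)c1cc(C(F)(F)F)cc(C(F)(F)F)c1` gives 75.5% in this assay, the highest of the three numbers; how its core differs from that of compound 1 is not broken down here.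

Compound 4 `COc1cc(Cl)cc(-c2nn(-c3cccc(NC(=O)c4cc(C(F)(F)F)cc(C(F)(F)F)c4)c3)cc2-c2ccncc2)c1` has not yet been measured. It differs from compound 3 by methyl in place of hydrogen on an oxygen on an aromatic ring, the same change that was made from compound 1 to compound 2, at a place described in the same words. The step from compound 3 to compound 4 is expected to point the same way as the earlier one but to be smaller, because compound 3 already starts at 75.5%, and because the earlier step was a number 50 percentage points higher from compound 1 to compound 2 (beyond the scatter) the expected change is a number 19.5 percentage points higher from compound 3 to compound 4 (beyond the scatter). The estimate for compound 4 is 95%, expected to fall between 70% and 120%.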

Compound 4, a percentage reported as activity, at one concentration (the size of the read-out at that concentration, not a potency): 80%
For compound 4 the middle estimate is 15 percentage points above the measured one; the range from low to high includes it.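

In this assay, replacing hydroxy with methoxy, which turns 3-chloro-5-hydroxyphenyl into 3-chloro-5-methoxyphenyl, gave a number 4.5 percentage points higher from compound 3 to compound 4 (within the scatter). Set beside the earlier step, the same change did not carry over at the same size from the core of compound 1 to the core of compound 3: the same change on two cores in this assay, a number 50 percentage points higher (beyond the scatter) from compound 1 to compound 2 and a number 4.5 percentage points higher (within the scatter) from compound 3 to compound 4, 45.5 percentage points apart, beyond the scatter of two such steps. For the compounds shown here, this shows that, in this series, the size of the step seen on one core cannot simply be transferred to another, but it rests on only two pairs, and it does not show which difference between the two cores matters or why the steps part.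

The compounds shown leave open how the change behaves on any further core, and so whether either step is the more typical one. They also leave open what other groups would do at the same place, such as an ethoxy group, a longer chain on the oxygen, or an amine in place of the hydroxy.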